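The compounds below may be only part of what the source reports. "The series", "measured", "known", "first", "only" and "open" are said of these compounds alone.

Compound 1 `O=C(NO)c1cccc(OCc2ccc(-c3ccccc3)cc2)c1` gives 19600 nM in an assay on isolated protein for inhibition of sphingomyelin phosphodiesterase (Homo sapiens), read by fluorescence, with a stated time of 30 min; on this read-out higher numbers stand for weaker inhibition and lower numbers for stronger inhibition. Compound 2 `O=C(NO)c1cccc(OCc2ccc(-c3ccc(Cl)cc3)cc2)c1` differs from compound 1 by chloro in place of hydrogen on an aromatic carbon, and in this assay compound 2 gives 8960 nM, a step of a 2.2-fold lower number from compound 1 to compound 2 (0.34 log units; beyond the scatter). Compound 3 `O=C(NO)c1cc(OCc2ccc(-c3ccccc3)cc2)no1` carries a different core; how the two cores differ is not broken down here. In this assay compound 3 gives 880 nM, the lowest number of the three measured, with its gaps to compound 1 and compound 2 both beyond the scatter. Compound 4 `O=C(NO)c1cc(OCc2ccc(-c3ccc(Cl)cc3)cc2)no1` is not yet measured; it differs from compound 3 by chloro in place of hydrogen on an aromatic carbon, the same change as that between compound 1 and compound 2, at a place described in the same words. A step of a 2.2-fold lower number from compound 3 to compound 4 (0.34 log units; beyond the scatter) is expected, resting on the measured 2.2-fold lower number from compound 1 to compound 2 (0.34 log units; beyond the scatter). Compound 4 is therefore estimated at 400 nM, within 200 nM to 900 nM.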

Compound 4, half-maximal inhibitory concentration: 320 nM
Compound 4: the middle estimate sits 1.3-fold (0.10 log units) above what was measured; the measured number falls inside the stated range.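

In this assay, phenyl to 4-chlorophenyl gives a 2.8-fold lower number from compound 3 to compound 4 (0.44 log units; beyond the scatter), and the step holds at a similar size on the second core: the same change on two cores in this assay, a 2.2-fold lower number (0.34 log units; beyond the scatter) from compound 1 to compound 2 and a 2.8-fold lower number (0.44 log units; beyond the scatter) from compound 3 to compound 4, 1.3-fold (0.10 log units) apart, within the scatter of two such steps On these two cores, the change can therefore be carried across with no measurable difference in its size. Two pairs do not show that it would carry to a further core, and they do not say what underlies the step.

Open, going by these compounds, is whether a methoxy group or an amine in place of the chloro would give matching steps on both cores. Also open, on these data alone, is whether chloro elsewhere on that six-membered aromatic ring would carry across in the same way.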